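The source may report more compounds than this note shows. Statements on the series, on what has been measured and on what is new or still open speak of the compounds shown alone.

Three compounds that share one core have been followed in an ADME assay on a cell-free system (plasma, Homo sapiens) for metabolic stability, read by HPLC; a higher number here means that the compound lasts longer, a lower number that the compound disappears faster. Compound 1 (`CCOC(=O)c1ccc(/N=N/N(C)C(=O)CCCCc2ccc(O)cc2)cc1`) gives 26.3 h, compound 2 (`Cc1ccc(/N=N/N(C)C(=O)CCCCc2ccc(O)cc2)cc1`) gives 79.7 h, and compound 3 (`CN(/N=N/c1ccc(Br)cc1)C(=O)CCCCc1ccc(O)cc1`) gives 162 h, the highest of the three numbers. The next compound, compound 4 (`CN(/N=N/c1ccc(C(N)=O)cc1)C(=O)CCCCc1ccc(O)cc1`), differs from compound 3 in a single place: carbamoyl in place of bromo on an aromatic carbon. Carbamoyl thus stands in place of bromo on an aromatic carbon.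

For the measured compounds named here, no measured step involves carbamoyl itself. Going by the values given here, the closest guide is the step involving ethoxycarbonyl, the only measured group that, like carbamoyl, holds a carbonyl: a 6.2-fold higher number from compound 1 to compound 3 (0.79 log units; beyond the scatter). The step from methyl to bromo is smaller, a 2.0-fold higher number from compound 2 to compound 3 (0.31 log units; beyond the scatter), and the step from ethoxycarbonyl to methyl is a 3.0-fold higher number from compound 1 to compound 2 (0.48 log units; beyond the scatter). All three are modest, and both steps that end at compound 3 rise towards it, so compound 3 offers little room for a further rise. Read in reverse, the step involving ethoxycarbonyl points to a lower number for compound 4. However, carbamoyl and ethoxycarbonyl are different groups, and three compounds are a thin basis, so only part of that step is assumed to carry over. The expected change is a 2.9-fold lower number from compound 3 to compound 4 (0.47 log units; beyond the scatter). For compound 4 the half-life is estimated at 55 h, with an expected range from 20 h to 130 h.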

Compound 4, half-life: 55.4 h
For compound 4 the middle estimate is 1.0-fold (0.00 log units) below the measured one; measured number inside the range.
By their numbers in this assay, from the lowest: compound 1; then compounds 4 and 2 (each within the scatter of the next); then compound 3.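

In this assay, carbamoyl on an aromatic carbon para to a large group gives up part of the number held with bromo (a 2.9-fold lower number from compound 3 to compound 4 (0.47 log units; beyond the scatter)), while it cannot be told apart from methyl at the same place (a 1.4-fold lower number from compound 2 to compound 4 (0.16 log units; within the scatter)). The carbonyl alone therefore does not set the number here: the two groups that hold one differ by a step beyond the scatter when amino stands in place of ethoxy on the carbonyl carbon (a 2.1-fold higher number from compound 1 to compound 4 (0.32 log units; beyond the scatter)). Nothing shown bears on why these steps take the sizes they do.

The four compounds leave open how groups such as a carboxylic acid, a nitrile or a methylamide would stand at this place, and whether a chlorine or an iodine would stay close to bromo. They also leave open whether the same order of groups would hold if the chain bearing the phenol or the methyl on the core's nitrogen were changed, since every comparison here rests on that one shared core.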